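Dimethylpyrimidinyl analogue of the acylthiourea series

The compounds below may be only part of what the source reports. "The series", "measured", "known", "first", "only" and "open" are said of these compounds alone.

Going by the values given here, compound 3 `Cc1cc(Cl)nc(NC(=S)NC(=O)c2c(-c3ccc(Cl)cc3Cl)noc2C)n1` gives the highest of the three numbers so far in a functional assay on the whole organism for inhibition, with Chenopodium ficifolium as the target, with a stated time of 72 h, tested at 10 mg/L (on this read-out higher numbers stand for more inhibition of growth at the one concentration tested and lower numbers for less inhibition of growth), namely 28.9%. Compound 2 `COc1cc(C)nc(NC(=S)NC(=O)c2c(-c3ccc(Cl)cc3Cl)noc2C)n1` gives 15.3% and compound 1 `COc1cc(SC)nc(NC(=S)NC(=O)c2c(-c3ccc(Cl)cc3Cl)noc2C)n1` gives -8.31%. The two measured steps that reach compound 3 are a number 13.6 percentage points higher from compound 2 to compound 3 (beyond the scatter) and a number 37.2 percentage points higher from compound 1 to compound 3 (beyond the scatter); the remaining step is a number 23.6 percentage points higher from compound 1 to compound 2 (beyond the scatter).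

Compound 4 `Cc1cc(C)nc(NC(=S)NC(=O)c2c(-c3ccc(Cl)cc3Cl)noc2C)n1` differs from compound 3 by methyl in place of chloro on an aromatic carbon. Among the compounds with values here, no measured step exchanges chloro for methyl directly. The closest guides are the gain from compound 2 to compound 3, where chloro entered for methoxy, and the gain from compound 1 to compound 2, where methyl entered for methylsulfanyl; both favour the small group over the larger one. Compound 4 keeps a small group, so the expectation is a number near that of compound 3, or somewhat lower toward compound 2, with no step beyond the scatter: a number 6.9 percentage points lower from compound 3 to compound 4 (within the scatter) is the expected step. Compound 4 is therefore estimated at 22% in this assay, with a range from 5% to 40%.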

Compound 4, percent growth inhibition at one concentration: 16.9%
Estimate against measurement, compound 4: 5.1 percentage points above; the measured number falls inside the stated range.
By their numbers in this assay, from the lowest: compound 1; then compounds 2 and 4 (each within the scatter of the next); then compound 3.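

In this assay the change from chloro to methyl on this aromatic carbon gives a number 12 percentage points lower from compound 3 to compound 4 (beyond the scatter) even though each group counts one heavy atom, so heavy-atom count alone does not order these groups. Methoxy to methyl at the same carbon gives a number 1.6 percentage points higher from compound 2 to compound 4 (within the scatter) and leaves chloro as the only one of the three groups here that separates from the others, with compound 2 and compound 4 not separated. The 4,6-dimethylpyrimidin-2-yl group still gives a number 25.2 percentage points higher from compound 1 to compound 4 (beyond the scatter) and so also stands clear of the 4-methoxy-6-(methylsulfanyl)pyrimidin-2-yl group of compound 1.

Nothing shown explains why chloro differs from methyl at this carbon. On these data alone, whether bromo, an amine or trifluoromethyl at this carbon would match or pass chloro remains open.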